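A few compounds are considered here, and "the series" means these few. Any claim that something is new, unique, unknown or untested is made for them only; others in the source may bear on it.

Measured compounds:
Compound 1, `Oc1nc2nonc2nc1Nc1ccc(SC(F)(F)F)cc1`: 1400 nM
Compound 2, `Cc1cccc(C)c1Nc1nc2nonc2nc1O`: a limit only, > 100000 nM

Among the compounds with values here, in an assay on mitochondria from L6 cells (Rattus norvegicus) for activation, with a stated time of 90 min (a lower number here means that less compound is needed, a higher number that more compound is needed for the effect), compound 1 gives 1400 nM and is the only compound with a number. Within the data shown here, compound 2 gives only a limit in this assay, > 100000 nM; this is the limit of > 100000 nM in this assay, at which 1 of the 2 values shown sits, not a measured number, so no step between the two can be sized, and the two values show only that compound 1 lies well inside the range where compound 2 does not register.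

Compound 3, `Oc1nc2nonc2nc1Nc1ccc(F)cc1`, is not yet measured. It differs from compound 1 by fluoro in place of (trifluoromethyl)sulfanyl on an aromatic carbon. The group that leaves is several atoms, the one that enters a single atom. Compound 3 is expected to need more compound than compound 1 in this assay, with a step from a 4.3-fold higher number from compound 1 to compound 3 (0.63 log units; beyond the scatter) estimated as a clear loss beyond the scatter. For compound 3 the expected value is 6000 nM, within 1500 nM to 30000 nM.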

Compound 3, half-maximal effective concentration: 38600 nM
For compound 3 the middle estimate is 6.4-fold (0.81 log units) below the measured one; the measured number lies above the stated range.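

Fluoro in place of (trifluoromethyl)sulfanyl on the aromatic carbon gives a 28-fold higher number from compound 1 to compound 3 (1.44 log units; beyond the scatter) in this assay and is the first step in this series that can be sized, so the group at this position matters strongly for the read-out. Compound 3 still gives a number rather than a limit, so the shared core with a single fluorine on this carbon keeps a measurable effect, though far weaker than with the larger group. Nothing shown here accounts for the size of this step.

From the compounds shown here alone, with only these two groups compared at this carbon, it stays open whether the loss follows the number of atoms in the group or something specific to the sulfur. Going by these compounds, how a chlorine, a methoxy or a trifluoromethyl on the same carbon would compare also remains open.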